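This account rests on a few compounds, and the source may have more. Where it says the series, first, only, none or still open, it means among the compounds named here.

Measured compounds:
compound 1 `COc1cc(N(Cc2nc3ccccc3[nH]2)S(=O)(=O)c2ccc(C)cc2)cc(OC)c1OC` — in a functional assay on MGC-803 cells (Homo sapiens) for inhibition, read by MTT assay, with a stated time of 48 h (a lower number here means a stronger inhibitor, a higher number a weaker inhibitor), compound 1 gives 1020 nM
compound 2 `COc1cc(N(Cc2nc3ccccc3[nH]2)C(=O)c2ccc(Br)cc2)cc(OC)c1OC` — in this assay compound 2 gives 14600 nM

For the measured compounds named here, compound 2 stands at the highest of the two numbers, with compound 1 as its only neighbour at the lower value. Going by the values given here, the single measured step, a 14-fold higher number from compound 1 to compound 2 (1.16 log units; beyond the scatter), concerns the group on the nitrogen and does not touch the change now at hand.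

Compound 3 `COc1cc(N(Cc2nc3ccccc3[nH]2)C(=O)c2cccc(Cl)c2)cc(OC)c1OC` carries 3-chlorophenyl in place of 4-bromophenyl on a carbonyl carbon. Among the compounds with values here, no measured step addresses this exchange, so the expectation is a step of no more than the scatter, a 1.2-fold lower number from compound 2 to compound 3 (0.09 log units; within the scatter). Compound 3 is therefore estimated at 12000 nM, within 4000 nM to 40000 nM.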

Compound 3, half-maximal inhibitory concentration: > 50000 nM
Compound 3: only a limit was reported; the forecaster's own chance of this, stated with the estimate: 15%; middle value at least 4.1-fold (0.61 log units) from the limit.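

In this assay compound 3 gives only a limit: the limit of > 50000 nM in this assay, at which 1 of the 3 values shown sits.

The group on the carbonyl carbon is therefore not interchangeable: 3-chlorophenyl in place of 4-bromophenyl gives an at least 3.4-fold higher number from compound 2 to compound 3 (0.53 log units; beyond the scatter). The gap to the sulfonyl compound also widens, with an at least 49-fold higher number from compound 1 to compound 3 (1.69 log units; beyond the scatter).

Both the halogen and its place on the ring change in this one step, so the compounds shown do not separate the two. As far as these compounds go, how an amine or a carboxylic acid in place of the halogen would read also stays open.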